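Methoxy in Place of Nitro on the Aryl Ring of Compound 3

The source may hold more compounds than are shown below. What is called first, only, known or untested is meant among the compounds shown, and "the series" means these compounds.

Three compounds have been tested in a functional assay on the whole organism (strain albino) for inhibition, with Rattus norvegicus as the target, read by paw edema, with stated times of 1 h and 2 h, at a dose of 200 mg/kg by the oral route; a higher number here means more inhibition at the dose given (going by the name of the read-out), a lower number less inhibition:
Compound 1 `O=c1oc2ccccc2cc1C1=NN(c2ccccc2)[C@@H](c2ccc(Cl)cc2Cl)C1` gives 56.7%.
Compound 2 `CN(C)c1ccc([C@H]2CC(c3cc4ccccc4oc3=O)=NN2c2ccccc2)cc1` gives 28.4%.
Compound 3 `O=c1oc2ccccc2cc1C1=NN(c2ccccc2)[C@@H](c2cccc([N+](=O)[O-])c2)C1` gives 26.1%.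

Compound 3 sits at the bottom end of these three values. The step of a number 2.3 percentage points lower from compound 2 to compound 3 (within the scatter) lies within the scatter, so compound 2 and compound 3 cannot be told apart, whereas a number 30.6 percentage points lower from compound 1 to compound 3 (beyond the scatter) is a clear drop. Compound 4 `COc1cccc([C@H]2CC(c3cc4ccccc4oc3=O)=NN2c2ccccc2)c1` differs from compound 3 by methoxy in place of nitro on an aromatic carbon. Among the measured compounds shown here, no measured step swaps nitro for methoxy. The two steps that bear on it, a number 28.3 percentage points lower from compound 1 to compound 2 (beyond the scatter) and a number 30.6 percentage points lower from compound 1 to compound 3 (beyond the scatter), show only that two quite different aryl groups land close to each other, well under compound 1. A change within the scatter is therefore expected, a number 3.9 percentage points higher from compound 3 to compound 4 (within the scatter). Compound 4 is estimated at 30%, between 17% and 45%.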

Compound 4, a percentage reported as inhibition, in the whole organism at one dose (the size of the read-out at that dose, not a potency): 38.3%
Compound 4: the middle estimate sits 8.3 percentage points below what was measured; low and high end bracket the measured number.
By their numbers in this assay, from the lowest: compounds 3, 2 and 4 (each within the scatter of the next, the first and the last beyond it); then compound 1.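

In this assay the group on this aromatic carbon proves able to shift the result by itself: methoxy in place of nitro gives a number 12.2 percentage points higher from compound 3 to compound 4 (beyond the scatter) and so separates two compounds that share everything else. Even so, a number 9.9 percentage points higher from compound 2 to compound 4 (within the scatter) leaves compound 4 indistinguishable from compound 2, while a number 18.4 percentage points lower from compound 1 to compound 4 (beyond the scatter) keeps the 2,4-dichlorophenyl group of compound 1 clearly ahead. No measurement available here accounts for the difference between methoxy and nitro.

On these data alone, it remains open how a hydroxyl or an amine on the same carbon would compare. Whether methoxy would give the same result elsewhere on this ring is also unknown.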